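A few compounds are considered here, and "the series" means these few. Any claim that something is new, unique, unknown or untested is made for them only; others in the source may bear on it.

Three members of one series of aryl-substituted aminothiadiazoles have been examined in an assay on isolated protein for inhibition of beta-glucuronidase (Bos taurus), read by spectrophotometry, with a stated time of 30 min; on this read-out lower numbers stand for stronger inhibition and higher numbers for weaker inhibition. Compound 1 `COc1ccc(Nc2nnc(-c3ccccc3Cl)s2)cc1` gives 22600 nM in this assay. Compound 2 `COc1ccccc1-c1nnc(Nc2ccc(Cl)c(Cl)c2)s1` gives 22600 nM in this assay. Compound 3 `Cc1ccc(Nc2nnc(-c3ccc(C(C)(C)C)cc3)s2)cc1` gives 26300 nM in this assay. Taken together, the three numbers sit close to one another: the number for compound 3 lies within the usual scatter of the number for compound 1 and likewise within the scatter of the number for compound 2, so the three compounds cannot be separated on these data, and none of them is notably stronger or weaker than the others.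

The next compound to be considered is compound 4 `CC(C)(C)c1ccc(-c2nnc(Nc3ccc(Br)cc3)s2)cc1`. It differs from compound 3 in a single place, where (bromo in place of methyl on an aromatic carbon). Among the measured compounds there is no pair that differs in just this one place, so nothing measured speaks directly to what this exchange does in this assay. For the measured compounds named here, since every number so far falls in one narrow band, the step from compound 3 to compound 4 is expected to be small, most likely no larger than the scatter in either direction, giving an expected step of a 1.2-fold lower number from compound 3 to compound 4 (0.08 log units; within the scatter). Compound 4 is therefore estimated to give about 22000 nM in this assay, with a plausible range from 9000 nM to 55000 nM.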

Compound 4, half-maximal inhibitory concentration: 32200 nM
Beside the measured number, compound 4's estimate is 1.5-fold (0.17 log units) below it; measured number inside the range.
By their numbers in this assay, from the lowest: compounds 1, 2, 3 and 4 (each within the scatter of the next).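

In this assay, for the compounds shown here, bromo in place of methyl on an aromatic carbon, para to a large group, gives a 1.2-fold higher number from compound 3 to compound 4 (0.09 log units; within the scatter), the first step that can be read at a single place. At this position, therefore, methyl and bromo cannot be told apart on this read-out: exchanging the 4-methylphenyl for the 4-bromophenyl, with one heavy atom leaving, one entering and no hydrogen-bond donor or acceptor on either side, leaves the two compounds within the scatter of each other. No measurement available here accounts for this result or bears on this step.

Only methyl and bromo can be compared at this position, so it remains open whether an amine, a carboxylic acid or a longer chain in the same place would also stay within the scatter of these compounds or would separate clearly from them. From the compounds shown here alone, the exchange has also been read only once, with the 4-tert-butylphenyl group on the other side of the shared core, so whether it would read the same with a different group there is unknown.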